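The source may hold more compounds than are shown below. What is called first, only, known or untested is meant among the compounds shown, and "the series" means these compounds.

Of the compounds shown here, two have so far been measured in an ADME assay for metabolic stability, at pH 1.5; on this read-out higher numbers stand for a longer-lived compound and lower numbers for a shorter-lived compound. Compound 1 `Nc1ncnc2c1ncn2C1CCC(COP2(=O)OCc3ccccc3O2)O1` gives 0.6 h in this assay. Compound 2 `Cc1cc(C)c2c(c1)COP(=O)(OCC1CCC(n3cnc4c(N)ncnc43)O1)O2` gives 0.73 h in this assay. Among the compounds with values here, compound 1 therefore carries the lower of the two numbers, but its only neighbour, compound 2, sits within the scatter of it, so the two half-lives cannot be told apart and no ordering between them can be claimed.

Compound 3 `COc1ccc2c(c1)COP(=O)(OCC1CCC(n3cnc4c(N)ncnc43)O1)O2` has not yet been measured in this assay. It differs from compound 1 in one place: methoxy in place of hydrogen on an aromatic carbon. Within the data shown here, no pair of measured compounds that differ in a single place is available, so there is no measured step to lean on for this change. What is known is only that the two measured half-lives lie close together.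

On that basis compound 3 is expected to give 0.65 h in this assay, with a range of 0.35 h to 1.2 h. The expected step of a 1.1-fold higher number from compound 1 to compound 3 (0.03 log units; within the scatter) is estimated to stay within the scatter, with no clear direction.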

Compound 3, half-life: 0.8 h
Compound 3: middle estimate off by 1.2-fold (0.09 log units), on the low side; the measured number falls inside the stated range.
By their numbers in this assay, from the lowest: compounds 1, 2 and 3 (each within the scatter of the next).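

The step from hydrogen to methoxy gives the series its first single-place comparison in this assay: a 1.3-fold higher number from compound 1 to compound 3 (0.12 log units; within the scatter). At this position, on an aromatic carbon of the six-membered aromatic ring of carbon only, part of the fused system, the methoxy group therefore leaves the half-life indistinguishable from that of the unsubstituted compound, and no direction can be claimed for the change. Within the data shown here, nothing measured here accounts for this outcome, and the single step cannot say what lies behind it.

As far as these compounds go, it remains open whether any other group on this aromatic carbon, such as an amine, a carboxylic acid or a longer chain like butoxy, would give a step beyond the scatter, or whether every replacement here would stay as close to compound 1 as methoxy does. From the compounds shown here alone, it is also open whether methoxy on another carbon of the same ring would behave as it does here, since one step at one position gives no pattern for the ring as a whole.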